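A few compounds are considered here, and "the series" means these few. Any claim that something is new, unique, unknown or untested is made for them only; others in the source may bear on it.

Of the compounds shown here, three built on a shared core have been measured in a functional assay on OVCAR-3 cells (Homo sapiens) for antiproliferative activity, read by MTT assay, with a stated time of 24 h; a higher number here means a weaker inhibitor, a lower number a stronger inhibitor. Compound 1 `Cc1cccc(NNC(=O)c2ccccc2NS(=O)(=O)c2cnc(O)nc2O)c1` gives > 20000 nM, which is a limit of the assay and not a number. Compound 2 `O=C(NNc1cccc(Cl)c1)c1ccccc1NS(=O)(=O)c1cnc(O)nc1O` gives 5520 nM. Compound 3 `CCCCOc1ccc(C(=O)NNC(=O)c2ccccc2NS(=O)(=O)c2cnc(O)nc2O)cc1` gives 5010 nM, which lies within the scatter of compound 2, so these two cannot be ranked against each other.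

Compound 4 `Cc1ccccc1C(=O)NNC(=O)c1ccccc1NS(=O)(=O)c1cnc(O)nc1O` has not yet been measured. It differs from compound 3 in one place, with 2-methylphenyl in place of 4-butoxyphenyl on a carbonyl carbon.

Going by the values given here, only one measured step offers any guide. In an at least 3.6-fold lower number from compound 1 to compound 2 (0.55 log units; beyond the scatter), chloro replaces methyl on an aromatic carbon, and the size of that step lies beyond the scatter. Among the compounds with values here, it is not the same change as the one at hand, so it shows only that a small swap on an aromatic ring can matter in this assay. It also leaves the methyl-bearing compound at the weak end of the series, so a modest move to a higher number is expected, an estimated 2.2-fold higher number from compound 3 to compound 4 (0.34 log units; beyond the scatter). For compound 4 the expected value is 11000 nM, with an estimated range of 4000 nM to 20000 nM.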

Compound 4, half-maximal inhibitory concentration: > 20000 nM
Compound 4 gave a limit, no number (the forecaster's own chance of this, stated with the estimate: 30%); middle value at least 1.8-fold (0.25 log units) away from the limit.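

In this assay, going by these compounds alone, the change from 4-butoxyphenyl to 2-methylphenyl on a carbonyl carbon gives an at least 3.9-fold higher number from compound 3 to compound 4 (0.60 log units; beyond the scatter), the first sign in these compounds that the group at this position matters; until now the only readable step was a swap of chloro for methyl on an aromatic carbon. Compound 4 gives > 20000 nM, which is a limit of the assay and not a number. Putting (2-methylphenyl)carbonyl in place of 3-chlorophenyl on an amine nitrogen gives an at least 3.6-fold higher number from compound 2 to compound 4 (0.55 log units; beyond the scatter), so a carbonyl at this place does not by itself secure a measurable value: compound 3 carries one and gives a number, while compound 4 carries one and gives a limit.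

Going by these compounds, the step between compound 1 and compound 4 cannot be read because both values are limits: the limit of > 20000 nM in this assay, at which 2 of the 4 values shown sit. Whether the butoxy chain or the place of the methyl decides the outcome stays open, and a longer alkoxy chain, an amine or a carboxylic acid on that aromatic ring would help to separate the two.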